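A few compounds are considered here, and "the series" means these few. Any claim that something is new, unique, unknown or untested is made for them only; others in the source may bear on it.

Compound 1 `CCCN(CCC)c1nc(C(C)(C)C)ccc1CNC(=O)C(C)c1ccc(NS(C)(=O)=O)c(F)c1` gives 2.5 nM in an assay on cells for antagonist activity at transient receptor potential cation channel subfamily V member 1 (Homo sapiens), read by FLIPR and calcium flux, with a stated time of 6 min; on this read-out higher numbers stand for weaker inhibition and lower numbers for stronger inhibition.
Compound 2 `CC(C)CCOc1nc(C(C)(C)C)ccc1CNC(=O)C(C)c1ccc(NS(C)(=O)=O)c(F)c1` gives 0.8 nM.
Compound 3 `CC(C(=O)NCc1ccc(C(C)(C)C)nc1SC1CCCC1)c1ccc(NS(C)(=O)=O)c(F)c1` gives 2.5 nM.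

Among these three, compound 2 stands at the lowest number: the steps to both neighbours go up, a 3.1-fold higher number from compound 2 to compound 3 (0.49 log units; beyond the scatter) and, read in the other direction, a 3.1-fold lower number from compound 1 to compound 2 (0.49 log units; beyond the scatter). Compound 4 `COc1ccc(CSc2nc(C(C)(C)C)ccc2CNC(=O)C(C)c2ccc(NS(C)(=O)=O)c(F)c2)cc1` has not yet been tested in this assay. Its change from compound 2 is (4-methoxybenzyl)sulfanyl in place of isopentyloxy on an aromatic carbon. The measured step that bears on it most closely is the exchange of isopentyloxy for cyclopentylsulfanyl, where a 3.1-fold higher number from compound 2 to compound 3 (0.49 log units; beyond the scatter); alongside it, no change at the digits printed from compound 1 to compound 3 (within the scatter). For the measured compounds named here, no measured compound carries the (4-methoxybenzyl)sulfanyl group itself, so the larger group is an extrapolation. On this basis compound 4 is expected to read modestly higher than compound 2, a step of about a 3.1-fold higher number from compound 2 to compound 4 (0.49 log units; beyond the scatter). Compound 4 is therefore estimated at 2.5 nM, with a range from 0.8 nM to 7 nM.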

Compound 4, inhibition constant: 3.5 nM
Compound 4: middle estimate off by 1.4-fold (0.15 log units), on the low side; the measured number falls inside the stated range.
By their numbers in this assay, from the lowest: compound 2; then compounds 1, 3 and 4 (each within the scatter of the next).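

The position next to the ring nitrogen also takes the larger (4-methoxybenzyl)sulfanyl group, which brings in a six-membered aromatic ring of carbon only, without a step beyond the scatter from either of two other groups: a 1.4-fold higher number from compound 3 to compound 4 (0.15 log units; within the scatter) and a 1.4-fold higher number from compound 1 to compound 4 (0.15 log units; within the scatter) in this assay. Isopentyloxy alone stands apart from it, with a 4.4-fold higher number from compound 2 to compound 4 (0.64 log units; beyond the scatter) so the step up from compound 2 now holds for two sulfanyl groups rather than one. Nothing available gives a reason for these steps.

The compounds shown leave open whether the step goes with the oxygen link or with the isopentyl chain, which an isopentylsulfanyl or a 4-methoxybenzyloxy group at this position would address. Also open, going by these compounds, is what a carboxylic acid or an amine in place of the methoxy group would do.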